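Replacing a furan ketone with a methyl ester on a bicyclic amine

The source may report more compounds than this note shows. Statements on the series, on what has been measured and on what is new or still open speak of the compounds shown alone.

Measured so far:
compound 1 `C[C@@H]1C[C@H]1C(=O)N1CC2CNCC2C1`: 360 nM
compound 2 `O=C(C1CC1)[C@H]1C[C@H]2CNC[C@H]2C1`: 70 nM
compound 3 `O=C(c1ccco1)[C@H]1C[C@H]2CNC[C@H]2C1`: 2200 nM

In an assay on CHO cells for displacement of a labelled ligand from Neuronal acetylcholine receptor; alpha3/beta4 (Homo sapiens), read by scintillation counting, with a stated time of 2 h (on this read-out lower numbers stand for stronger inhibition and higher numbers for weaker inhibition), compound 3 gives the highest number of the three, so it binds most weakly. Compound 1 sits nearer to it, and compound 2 furthest away with the lowest number.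

Compound 4 `COC(=O)[C@H]1C[C@H]2CNC[C@H]2C1` differs from compound 3 by methoxy in place of furan-2-yl on a carbonyl carbon. For the measured compounds named here, the only measured step that touches the same carbonyl carbon is a 31-fold higher number from compound 2 to compound 3 (1.50 log units; beyond the scatter), in which a small saturated ring was exchanged for the furan-2-yl group and the number rose sharply. Compound 4 removes the furan-2-yl again, so a step back downward is expected, though not necessarily all the way to compound 2, since methoxy is not cyclopropyl and no ester has been measured here.

The step from compound 3 to compound 4 is therefore expected to be a 5.5-fold lower number from compound 3 to compound 4 (0.74 log units; beyond the scatter). For compound 4 in this assay a value of about 400 nM is estimated, with a likely range from 80 nM to 2000 nM.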

Compound 4, inhibition constant: 400 nM
Compound 4: middle estimate and measured number agree at the digits printed; low and high end bracket the measured number.
By their numbers in this assay, from the lowest: compound 2; then compounds 1 and 4 (each within the scatter of the next); then compound 3.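

In this assay, this carbonyl carbon now has three measured groups on the same core, and exchanging furan-2-yl for methoxy recovers a clear part of the binding (a 5.5-fold lower number from compound 3 to compound 4 (0.74 log units; beyond the scatter)). Methoxy does not match cyclopropyl, however (a 5.7-fold higher number from compound 2 to compound 4 (0.76 log units; beyond the scatter)), so the two non-aromatic groups at this place are not interchangeable, and removing the furan-2-yl is not enough on its own to reach the number of compound 2. The data offer no measured explanation for this order of the three groups.

From the compounds shown here alone, it remains open whether a longer ester such as ethoxy, or an amide carrying a dimethylamino group on the same carbonyl carbon, would fall nearer to compound 2 or to compound 4. The effect of a phenyl ketone, compared with the furan-2-yl ketone of compound 3, is also unresolved.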